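Cathepsin S nitrile series: fused aromatic ring variation

The source may hold more compounds than are shown below. What is called first, only, known or untested is meant among the compounds shown, and "the series" means these compounds.

Measured compounds:
compound 1 `CC1CCC(C[C@H](CC(=O)N2CCOCC2)C(=O)N[C@]2(C#N)CCN(C3CCCCC3)C2)CC1`: 13.8 nM
compound 2 `N#C[C@H](CCc1ccccc1)NC(=O)[C@@H](CC(=O)N1CCOCC1)CC1CCCCC1`: 25 nM
compound 3 `N#C[C@@]1(NC(=O)[C@@H](CC(=O)N2CCOCC2)CC2CCCCC2)CCN(C2CCCCCC2)C1`: 11 nM

In an assay on isolated protein for inhibition of cathepsin S (Homo sapiens) (on this read-out higher numbers stand for weaker binding and lower numbers for tighter binding), compound 1 gives 13.8 nM, the second highest of the three numbers. Compound 3 gives 11 nM and compound 2 gives 25 nM; both lie within the usual scatter of compound 1, so no order among the three can be read from these values.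

Compound 4 `N#C[C@@]1(NC(=O)[C@@H](CC(=O)N2CCOCC2)CC2CCc3ccccc3C2)CCN(C2CCCCC2)C1` is not yet measured. It differs from compound 1 by 1,2,3,4-tetrahydronaphthalen-2-yl in place of 4-methylcyclohexyl on a saturated chain carbon, two bonds along the chain from a carbonyl carbon. Among the compounds with values here, no measured pair shows this change, so its size is unknown from the data at hand; no step beyond the scatter is expected in this assay in either direction. For compound 4 the expected value in this assay is 13 nM, in the range 4 nM to 40 nM. The expected step of a 1.1-fold lower number from compound 1 to compound 4 (0.03 log units; within the scatter) is small.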

Compound 4, dissociation constant: 5.4 nM
Beside the measured number, compound 4's estimate is 2.4-fold (0.38 log units) above it; low and high end bracket the measured number.
By their numbers in this assay, from the lowest: compound 4; then compounds 3, 1 and 2 (each within the scatter of the next, the first and the last beyond it).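

In this assay, within the data shown here, 1,2,3,4-tetrahydronaphthalen-2-yl in place of 4-methylcyclohexyl gives a 2.6-fold lower number from compound 1 to compound 4 (0.41 log units; beyond the scatter) as the first step beyond the scatter. This position on the saturated chain carbon therefore takes the larger group, with its added six-membered aromatic ring, without loss of binding. Nothing at hand bears on the reason for this step.

Going by these compounds, whether a fused pyridine ring, or an amine on the aromatic ring, would keep this binding remains open. Also open, on these data alone, is whether the step carries over to another core, such as that of compound 2.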